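The compounds below may be only part of what the source reports. "The series", "measured", "known", "first", "only" and "open" are said of these compounds alone.

Notes on the series. Compound 1 `CCCc1nc(C)c2cnn(CC(O)CO)c(=O)n12`, compound 3 `CCCc1nc(C)c2c(C)nn(CC(O)CO)c(=O)n12` and compound 2 `CCCc1nc(C)c2c(C)nnc(S)n12` have been measured in a functional assay for inhibition, with Homo sapiens as the target; on this read-out lower numbers stand for stronger inhibition and higher numbers for weaker inhibition; compound 4 `CCCc1ncc2c(C)nnc(S)n12` has not. In this assay compound 3 reaches only the limit of the assay, > 48000 nM. In this assay compound 1 likewise stops at the assay limit, > 48000 nM. Within the data shown here, compound 2 is the one member with a number in this assay, giving 45000 nM. The difference between the core of compound 2 and the core of compound 3 is not broken down here.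

The change from compound 3 to compound 1 is hydrogen in place of methyl on an aromatic carbon. The step that the two limits leave unreadable from compound 3 to compound 1 cannot be read because the limit of > 48000 nM in this assay, at which 2 of the 3 values shown sit, is where two of the three values sit. From compound 2 to compound 4 the change is hydrogen in place of methyl on an aromatic carbon, the same kind of change, but the place differs: in compound 3 it sits on a six-membered aromatic ring with 3 nitrogen, meta to a 2,3-dihydroxypropyl group, whereas in compound 2 it sits on a five-membered aromatic ring with 2 nitrogen, two ring bonds from the ring atom that bears a propyl group.

In this assay the expected step is a 1.1-fold higher number from compound 2 to compound 4 (0.05 log units; within the scatter), kept small as compound 2 gives 45000 nM and the measured step that the two limits leave unreadable from compound 3 to compound 1 is not readable. Compound 4 is estimated at 50000 nM, within 15000 nM to 150000 nM, with a real chance that only a limit is returned.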

Compound 4, half-maximal inhibitory concentration: > 48000 nM
Compound 4 ended at the assay's limit; the forecaster's own chance of this, stated with the estimate: 55%; the middle value is on the limit's open side.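

In this assay the new step is an at least 1.0-fold higher number from compound 2 to compound 4 (0.02 log units; that floor lies within the scatter), so it gives only a floor, and that floor says nothing about how far the two compounds actually lie apart. Compound 4 ends at a limit of the assay, > 48000 nM, and not at a number. Hydrogen in place of methyl on an aromatic carbon therefore shows no measurable gain in inhibition on the core of compound 2, but the same change on the core of compound 3 gives a step to compound 1 that cannot be read, so neither core yields a size for this change and whether its effect carries from one core to the other stays unanswered, because the values pile up at the assay's ceiling: the limit of > 48000 nM in this assay, at which 3 of the 4 values shown sit.

The compounds shown leave open whether any member of the series can give inhibition clearly stronger than that of compound 2, at 45000 nM, which is the only number in the set. They also leave open what an amine or a carboxylic acid in place of the 2,3-dihydroxypropyl group, or a longer chain in place of the propyl group, would give in this assay.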